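This account rests on a few compounds, and the source may have more. Where it says the series, first, only, none or still open, it means among the compounds named here.

In a functional assay on the whole organism with Mus musculus as the target, in the maximal electroshock model, with a stated time of 120 min (on this read-out higher numbers stand for an effect only at larger amounts of compound and lower numbers for an effect already at smaller amounts), compound 2 `CCCCc1cccc(N2CCNCC2)n1` gives 30 mg/kg and compound 3 `CCCCSc1cccc(N2CCNCC2)n1` gives 100 mg/kg, the higher of the two numbers, separated by a 3.3-fold higher number from compound 2 to compound 3 (0.52 log units; beyond the scatter). Compound 1 `CCCCCCC(CCCCCC)c1cccc(N2CCNCC2)n1` reaches only the limit > 300 mg/kg, which is not a number; this is the only such case, (the limit of > 300 mg/kg in this assay, at which 1 of the 3 values shown sits). Compound 4 `CCCCCc1cccc(N2CCNCC2)n1` is not yet measured and differs from compound 3 in one place: pentyl in place of butylsulfanyl on an aromatic carbon. Among the measured compounds shown here, the one measured step that bears on this is a 3.3-fold higher number from compound 2 to compound 3 (0.52 log units; beyond the scatter), a modest rise, and the present change removes the butylsulfanyl again, so a modest fall back toward compound 2 is expected. Compound 4 is estimated at 40 mg/kg, ranging from 15 mg/kg to 100 mg/kg. The expected step is a 2.5-fold lower number from compound 3 to compound 4 (0.40 log units; beyond the scatter).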

Compound 4, minimum effective dose: 10 mg/kg
Beside the measured number, compound 4's estimate is 4.0-fold (0.60 log units) above it; the measured number lies below the stated range.
By their numbers in this assay, from the lowest: compound 4; then compound 2; then compound 3. At a limit, above all of these: compound 1.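

In this assay, pentyl in place of butylsulfanyl brings a 10-fold lower number from compound 3 to compound 4 (1.00 log units; beyond the scatter) and so undoes more than the earlier rise: at this position the all-carbon chain goes with an effect at smaller amounts than the sulfur chain. Extending butyl to pentyl also brings a 3.0-fold lower number from compound 2 to compound 4 (0.48 log units; beyond the scatter), so the number falls between these two chains. Compound 1 stays at a limit, which is not a number: the limit of > 300 mg/kg in this assay, at which 1 of the 4 values shown sits.

As far as these compounds go, it remains open whether hexyl would lower the number further or raise it again. Also open, from the compounds shown here alone, is how butoxy, with an ether oxygen, would compare with butylsulfanyl.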